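The compounds below may be only part of what the source reports. "The series", "measured", "known", "first", "only" and "open" are said of these compounds alone.

Measured in a functional assay on HCT-116 cells (Homo sapiens) for inhibition, read by CCK-8 assay, with a stated time of 48 h; on this read-out higher numbers stand for weaker inhibition and lower numbers for stronger inhibition:
- compound 1 `COc1cc(-c2ccnc3cc(-c4ccc(F)cc4)nn23)cc(OC)c1OC`: 5030 nM
- compound 2 `COc1cc(-c2ccnc3cc(-c4cn(CO)c5ccccc45)nn23)cc(OC)c1OC`: 128 nM
- compound 3 `COc1cc(-c2ccnc3cc(-c4c[nH]c5ccccc45)nn23)cc(OC)c1OC`: 35 nM

Compound 3 has the lowest number of the three, and its gaps to both other compounds lie beyond the scatter. The next compound, compound 4 `COc1cc(-c2ccnc3cc(-c4ccc(Cl)cc4)nn23)cc(OC)c1OC`, has 4-chlorophenyl in place of 1H-indol-3-yl on an aromatic carbon of the core: 4-chlorophenyl in place of 1H-indol-3-yl on an aromatic carbon.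

For the measured compounds named here, the closest precedent is the step of a 140-fold lower number from compound 1 to compound 3 (2.16 log units; beyond the scatter). This large step swapped 4-fluorophenyl for 1H-indol-3-yl at that same place, and the change to compound 4 runs the opposite way, back to a para-free description of a halogen-bearing phenyl group. The other measured step, a 3.7-fold lower number from compound 2 to compound 3 (0.56 log units; beyond the scatter), is modest and concerns hydrogen in place of hydroxymethyl on an aromatic nitrogen, so it says little about this swap. Going by the values given here, no measurement yet compares 4-chlorophenyl with 4-fluorophenyl directly, which leaves some uncertainty. A large step toward a higher number, meaning weaker inhibition, is therefore expected, with compound 1 at 5030 nM as the best guide. The estimate amounts to an expected 130-fold higher number from compound 3 to compound 4 (2.11 log units; beyond the scatter). For compound 4 the expected value is 4500 nM, with an estimated range from 1500 nM to 13000 nM.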

Compound 4, half-maximal inhibitory concentration: 3340 nM
Compound 4: the middle estimate sits 1.3-fold (0.13 log units) above what was measured; the range from low to high includes it.
By their numbers in this assay, from the lowest: compound 3; then compound 2; then compounds 4 and 1 (each within the scatter of the next).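

In this assay, the change of 1H-indol-3-yl to 4-chlorophenyl on this aromatic carbon of the core gives a 95-fold higher number from compound 3 to compound 4 (1.98 log units; beyond the scatter) and so repeats the large gap seen with the fluoro compound, now with a second halogen-bearing phenyl group. For the compounds shown here, the step with chloro in place of fluoro, a 1.5-fold lower number from compound 1 to compound 4 (0.18 log units; within the scatter) and thus too small to count as a real difference, shows something the earlier compounds could not: at this place, these two halogens on the phenyl ring cannot be told apart. Among compounds 1, 3 and 4, the large gap therefore goes with the choice between 1H-indol-3-yl and a halogen-bearing phenyl group, not with which of the two halogens the phenyl group carries.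

As far as these compounds go, it remains open whether a phenyl group carrying an amine or a hydroxyl group in place of the halogen, or a smaller ring such as pyrrol-3-yl, would give numbers nearer to that of compound 3. Nothing available here accounts for the wide gap between the indole and the halogen-bearing phenyl groups.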